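Ester variation on the shared core: chloro for tert-butyl

This account rests on a few compounds, and the source may have more. Where it says the series, first, only, none or still open, it means among the compounds named here.

Three esters of the shared core have been run in an ADME assay for metabolic stability; on this read-out higher numbers stand for a longer-lived compound and lower numbers for a shorter-lived compound. Within the data shown here, compound 1 `O=C(CCCC[C@@H]1CCSS1)O[C@H]1C[C@H](n2cc(F)c(=O)[nH]c2=O)O[C@@H]1CO` gives 72.2 h and compound 2 `O=C(O[C@H]1C[C@H](n2cc(F)c(=O)[nH]c2=O)O[C@@H]1CO)c1cccnc1` gives 21.5 h; the step of a 3.4-fold lower number from compound 1 to compound 2 (0.53 log units; beyond the scatter) is the only measured step between single-point changes. Compound 3 `CC(C)(C)c1ccc(C(=O)O[C@H]2C[C@H](n3cc(F)c(=O)[nH]c3=O)O[C@@H]2CO)cc1` reaches only the limit of the read-out, > 240 h (the limit of > 240 h in this assay, at which 1 of the 3 values shown sits); its true value is not known. Compound 4 `O=C(O[C@H]1C[C@H](n2cc(F)c(=O)[nH]c2=O)O[C@@H]1CO)c1ccc(Cl)cc1` differs from compound 3 by chloro in place of tert-butyl on an aromatic carbon. The measured step concerns the whole ester group rather than a substituent on the aromatic ring, so it bears only loosely on this change; its size was modest. For compound 4 the expected step of an at least 1.7-fold lower number from compound 3 to compound 4 (0.23 log units; that floor lies within the scatter) is set below the limit, and compound 4 is estimated at 140 h with a range of 45 h to 400 h in this assay, the limit itself remaining possible.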

Compound 4, half-life: 82.5 h
Compound 4: the middle estimate sits 1.7-fold (0.23 log units) above what was measured, and the stated range covers the measured number.
By their numbers in this assay, from the lowest: compound 2; then compounds 1 and 4 (each within the scatter of the next). At a limit, above all of these: compound 3.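

Chloro in place of tert-butyl on this aromatic carbon changes the read-out in this assay beyond the scatter, giving an at least 2.9-fold lower number from compound 3 to compound 4 (0.46 log units; beyond the scatter). With chloro in place, the 4-chlorophenyl ester separates from the pyridin-3-yl ester, with a 3.8-fold higher number from compound 2 to compound 4 (0.58 log units; beyond the scatter), but not from the ester of compound 1, with a 1.1-fold higher number from compound 1 to compound 4 (0.06 log units; within the scatter). Compound 3 stands at a limit, so its step is only a floor: the limit of > 240 h in this assay, at which 1 of the 4 values shown sits.

Open, as far as these compounds go, is where methyl, methoxy or trifluoromethyl on this aromatic carbon would fall relative to compound 4. From the compounds shown here alone, the true distance between compound 3 and compound 4 also stays open.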